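From Methoxy to Cyclopropyloxy: One Change, One Guide

The source may hold more compounds than are shown below. What is called first, only, known or untested is meant among the compounds shown, and "the series" means these compounds.

For the measured compounds named here, in a functional assay on HCT-116 cells (Homo sapiens) for antiproliferative activity, read by MTT assay, with a stated time of 48 h (a higher number here means a weaker inhibitor, a lower number a stronger inhibitor), compound 2 `COc1cc(-c2nnc3c(OC)cc(-c4ccc5[nH]ccc5c4)cn23)cc(OC)c1OC` gives 108 nM, the lowest of the three numbers measured so far. Compound 1 `CCOc1cc(-c2ccc3cc[nH]c3c2)cn2c(-c3cc(OC)c(OC)c(OC)c3)nnc12` gives 1340 nM, and compound 3 `COc1cc(-c2nnc3c(OC4COC4)cc(-c4ccc5[nH]ccc5c4)cn23)cc(OC)c1OC` gives 5370 nM. Both numbers are higher than that of compound 2, beyond the scatter.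

Compound 4 `COc1cc(-c2nnc3c(OC4CC4)cc(-c4ccc5[nH]ccc5c4)cn23)cc(OC)c1OC` has not yet been measured. It differs from compound 2 in one place: cyclopropyl in place of methyl on an oxygen on an aromatic ring. In words, this is cyclopropyl in place of methyl on an oxygen on an aromatic ring, or methoxy to cyclopropyloxy.

One measured step changes the same group. It is a 50-fold higher number from compound 2 to compound 3 (1.70 log units; beyond the scatter), a large step beyond the scatter, with oxetan-3-yl in place of methyl on that oxygen. Compound 1 gives weaker support, since it carries ethoxy but also differs from compound 2 elsewhere. Compound 1 nevertheless gives 1340 nM, which lies on the same side of compound 2. Neither compound contains the cyclopropyl group, so the size of the change remains uncertain.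

A rise in the number is therefore expected in this assay, though a smaller one than compound 3 showed. The expected step is a 9.3-fold higher number from compound 2 to compound 4 (0.97 log units; beyond the scatter), which would probably lie beyond the scatter. The estimated value for compound 4 is 1000 nM, with an expected range from 250 nM to 4500 nM.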

Compound 4, half-maximal inhibitory concentration: 275 nM
For compound 4 the middle estimate is 3.6-fold (0.56 log units) above the measured one, and the stated range covers the measured number.
By their numbers in this assay, from the lowest: compound 2; then compound 4; then compound 1; then compound 3.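

In this assay, this oxygen on an aromatic ring accepts a group larger than methyl at a much smaller cost than compound 3 alone suggested: a 2.5-fold higher number from compound 2 to compound 4 (0.41 log units; beyond the scatter) is a modest step, although it lies beyond the scatter and methyl keeps the lowest number of this set. The comparison between the two ring-bearing groups is sharper, as a 20-fold lower number from compound 3 to compound 4 (1.29 log units; beyond the scatter) is a large step, so the high number of compound 3 cannot be read as a penalty for any ring on this oxygen. The identity of the group matters here, not merely the replacement of methyl by a ring, but nothing shown gives a measured reason for the gap between cyclopropyl and oxetan-3-yl.

The compounds shown leave open whether a longer chain, such as propyl, or a chain ending in an amine on this oxygen would follow cyclopropyl or oxetan-3-yl, and whether any group here could give a lower number than methyl. They also leave open whether the same order would hold on a different core, since this single change was compared only on the core of compound 2.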